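This account rests on a few compounds, and the source may have more. Where it says the series, first, only, none or still open, it means among the compounds named here.

Measured compounds:
- compound 1, `COc1cc(OC)cc(N2CCN(C(=O)c3oc(C)nc3-c3cccc(F)c3)CC2)c1`: 28.2 nM
- compound 2, `Cc1nc(-c2ccccc2)c(C(=O)N2CCN(c3cccc(C#N)c3)CC2)o1`: 39.6 nM

Working notes on the series. Both measured compounds were run in a functional assay on HL-60 cells (Homo sapiens) for inhibition, read by MTT assay, with a stated time of 72 h; on this read-out lower numbers stand for stronger inhibition and higher numbers for weaker inhibition. Compound 1 gives 28.2 nM in this assay and compound 2 gives 39.6 nM. Compound 2 stands at the higher of the two numbers, but the gap to compound 1 is within the scatter, so the two compounds are not separated on this read-out. Going by the values given here, no step between measured compounds that differ in only one place exists in this set.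

Compound 3, `Cc1nc(-c2ccccc2)c(C(=O)N2CCN(c3cccc(F)c3)CC2)o1`, has not been measured in this assay. It differs from compound 2 by fluoro in place of cyano on an aromatic carbon, on an aromatic carbon of a six-membered aromatic ring of carbon only, meta to a large group.

Among the compounds with values here, with no matched step available, the size of the step from compound 2 to compound 3 cannot be read from the data. The change is small in what it removes and adds, so the step is expected to be modest, a 1.3-fold higher number from compound 2 to compound 3 (0.10 log units; within the scatter), and not clearly beyond the scatter in either direction. Compound 3 is estimated at 50 nM, with a range from 18 nM to 140 nM.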

Compound 3, half-maximal inhibitory concentration: 45 nM
Compound 3: middle estimate off by 1.1-fold (0.05 log units), on the high side; the range from low to high includes it.
By their numbers in this assay, from the lowest: compounds 1, 2 and 3 (each within the scatter of the next).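

The series now holds its first step that changes one place only: in this assay, fluoro in place of cyano on an aromatic carbon, meta to a large group, gives a 1.1-fold higher number from compound 2 to compound 3 (0.06 log units; within the scatter). This position therefore accepts both groups without separating them on this read-out, even though cyano leaves with 2 heavy atoms and 1 hydrogen-bond acceptor and fluoro enters with 1 heavy atom and 0 hydrogen-bond acceptors. No measurement on hand accounts for this outcome or speaks to its cause.

From the compounds shown here alone, whether a group of another kind at this same place, such as an amine, a carboxylic acid or a longer chain, would also stay within the scatter of compound 2 remains open, since cyano and fluoro alone cannot show how far the tolerance extends. Compound 1 differs from compound 2 and from compound 3 in more than one place, so the steps linking it to them cannot be read, and the contribution of each of its differing parts is unresolved.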